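Benzyl swap on compound 3 in a cell binding assay

This account rests on a few compounds, and the source may have more. Where it says the series, first, only, none or still open, it means among the compounds named here.

Measured compounds:
compound 1 `CCc1ccc(OCCC(O)CN(C)Cc2c(C)nn(Cc3ccccc3Cl)c2C)cc1` 26000 nM
compound 2 `Cc1nn(Cc2ccccc2Cl)c(C)c1CN(C)CC(O)CCOc1ccc(C(C)(C)C)cc1` 16700 nM
compound 3 `CCOc1ccc(OCCC(O)CN(C)Cc2c(C)nn(Cc3ccccc3F)c2C)cc1` "not active" (no number reported)

Among the compounds with values here, compound 1 and compound 2 are the only members with numbers in a binding assay on cells for antagonist activity at Toll-like receptor 4 (Homo sapiens), with a stated time of 24 h; a lower number here means a stronger inhibitor, a higher number a weaker inhibitor. Within the data shown here, the one comparable pair, tert-butyl in place of ethyl on an aromatic carbon, gives a 1.6-fold lower number from compound 1 to compound 2 (0.19 log units; within the scatter), so the series so far sits at weak inhibition without a resolved trend. Compound 3 stands apart: in this assay compound 3 is recorded as "not active" (no number reported), with no number to anchor it, which leaves its position relative to compound 1 and compound 2 undefined.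

Compound 4 `CCOc1ccc(OCCC(O)CN(C)Cc2c(C)nn(Cc3ccc(Cl)cc3)c2C)cc1` is the next compound. Relative to compound 3 the change is 4-chlorophenyl in place of 2-fluorophenyl on a saturated chain carbon bound to an aromatic nitrogen. Among the measured compounds shown here, no measured step touches this part of the molecule; the step from compound 1 to compound 2 concerns a different position and does not inform it. Compound 3 gave no number, so no direction can be read. On the weak numbers of compound 1 and compound 2, compound 4 is expected at about 30000 nM in this assay, with a broad range from 10000 nM to 100000 nM, and a real chance it again returns no number.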

Compound 4, half-maximal inhibitory concentration: 25900 nM
Compound 4: the middle estimate sits 1.2-fold (0.06 log units) above what was measured; low and high end bracket the measured number.
By their numbers in this assay, from the lowest: compounds 2, 4 and 1 (each within the scatter of the next).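

No new step can be read: compound 3 has no number, so the change from 2-fluorobenzyl to 4-chlorobenzyl leading to compound 4 at 25900 nM has no size. The compounds shown leave open whether the benzyl substituent shifts the number in this assay at all. No evidence at hand bears on this result.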